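Compound 3: a new group on the shared core

The source may hold more compounds than are shown below. What is called first, only, known or untested is meant among the compounds shown, and "the series" means these compounds.

Of the compounds shown here, two on the shared core have numbers so far. In an ADME assay on microsomes from liver (Homo sapiens) for metabolic stability, read by LC-MS, using NADPH, with stated times of 5 min and 30 min, tested at 1 uM (on this read-out lower numbers stand for slow clearance and higher numbers for fast clearance), compound 1 `O=C(Nc1ccccc1)c1cnc(NCc2c(F)ccc3c2CCO3)n2cnnc12` gives 14 mL.min-1.g-1 and compound 2 `CN(c1ccn(C)n1)c1cnc(NCc2c(F)ccc3c2CCO3)n2cnnc12` gives 11 mL.min-1.g-1 so the two stand within the scatter of each other. Compound 3 `C[C@H]1CC(=O)N(c2cnc(NCc3c(F)ccc4c3CCO4)n3cnnc23)C1` carries 4-methyl-2-oxopyrrolidin-1-yl in place of methyl(1-methyl-1H-pyrazol-3-yl)amino on an aromatic carbon. Among the compounds with values here, the only measured step at this aromatic carbon puts methyl(1-methyl-1H-pyrazol-3-yl)amino in place of phenylcarbamoyl. Resting on a 1.3-fold lower number from compound 1 to compound 2 (0.10 log units; within the scatter) alone, the expectation in this assay is no step beyond the scatter, although no measured compound carries 4-methyl-2-oxopyrrolidin-1-yl. The range is kept wide for that reason. For compound 3 the estimate is 12 mL.min-1.g-1 with an expected range of 5 mL.min-1.g-1 to 28 mL.min-1.g-1 around it. This estimate means a 1.1-fold higher number from compound 2 to compound 3 (0.04 log units; within the scatter) as the expected change.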

Compound 3, intrinsic clearance in microsomes: < 3 mL.min-1.g-1
Compound 3: only a limit was reported (the forecaster's own chance of this, stated with the estimate: 5%); middle value at least 4.0-fold (0.60 log units) from the limit.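

At this aromatic carbon the group in place does change the read-out in this assay: the earlier step from phenylcarbamoyl to methyl(1-methyl-1H-pyrazol-3-yl)amino stayed within the scatter, whereas 4-methyl-2-oxopyrrolidin-1-yl gives an at least 3.6-fold lower number from compound 2 to compound 3 (0.56 log units; beyond the scatter) and an at least 4.6-fold lower number from compound 1 to compound 3 (0.66 log units; beyond the scatter). The reported value for compound 3 is a limit and not a number, so the full size of both steps stays open: the limit of < 3 mL.min-1.g-1 in this assay, at which 1 of the 3 values shown sits.

Of the three groups at this place, only 4-methyl-2-oxopyrrolidin-1-yl has a non-aromatic ring, and this rests on compound 3 alone.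

The compounds shown do not separate the contributions of the 4-methyl group, the ring carbonyl and the defined stereocentre. Also open, going by these compounds, is how the read-out would respond to the unsubstituted 2-oxopyrrolidin-1-yl group, the opposite stereoisomer or an open-chain amide at the same aromatic carbon.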